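This account rests on a few compounds, and the source may have more. Where it says the series, first, only, none or still open, it means among the compounds named here.

Measured compounds:
- compound 1, `COc1cc2c(Nc3nc4ccc(C(=O)Nc5c(C)cccc5Cl)cc4s3)ncnc2cc1OCCCN1CCCCC1C`: 5300 nM
- compound 2, `CCN(CC)CCCOc1cc2ncnc(Nc3nc4ccc(C(=O)Nc5c(C)cccc5C)cc4s3)c2cc1OC`: 66500 nM

In a functional assay on NCI-H661 cells (Homo sapiens) for cytotoxicity, read by WST assay, with a stated time of 72 h (a higher number here means a weaker inhibitor, a lower number a stronger inhibitor), compound 2 gives 66500 nM, the higher of the two numbers recorded. Its nearest neighbour is compound 1, which in this assay gives 5300 nM; the gap between the two lies beyond the scatter. Compound 1 and compound 2 differ in two places, so their values alone do not say which part of the structure carries the gap.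

Compound 3, `CCN(CC)CCCOc1cc2ncnc(Nc3nc4ccc(C(=O)Nc5c(C)cccc5Cl)cc4s3)c2cc1OC`, has not yet been measured. It differs from compound 2 in one place, chloro in place of methyl on an aromatic carbon, ortho to a large group and meta to a methyl group. Compound 3 therefore carries the same 2-chloro-6-methylphenyl carbamoyl group as compound 1, while keeping the chain of compound 2.

Within the data shown here, since no single-point step between measured compounds is available, the expectation rests on the two values alone. Compound 3 is expected to land between them, with a step from compound 2 of a 3.3-fold lower number from compound 2 to compound 3 (0.52 log units; beyond the scatter) toward a lower number, beyond the scatter. The estimate for compound 3 in this assay is 20000 nM, within a range of 5000 nM to 60000 nM.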

Compound 3, half-maximal inhibitory concentration: 11200 nM
Compound 3: the middle estimate sits 1.8-fold (0.25 log units) above what was measured; the measured number falls inside the stated range.
By their numbers in this assay, from the lowest: compound 1; then compound 3; then compound 2.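

In this assay the change of methyl to chloro, on an aromatic carbon ortho to a large group and meta to a methyl group, can now be read on its own, and it gives a 5.9-fold lower number from compound 2 to compound 3 (0.77 log units; beyond the scatter) with the diethylamino chain held constant. With the 2-chloro-6-methylphenyl group held constant, diethylamino in place of 2-methylpiperidin-1-yl gives a 2.1-fold higher number from compound 1 to compound 3 (0.32 log units; beyond the scatter) in the same direction, and since both steps lie beyond the scatter, the gap between compound 1 and compound 2 is shown to involve both places rather than one. No supporting measurement bears on why either change shifts the number in this way.

Among these compounds, the chloro step is seen only with the diethylamino chain, so whether it is of similar size with 2-methylpiperidin-1-yl at the chain end stays open. Also open, going by these compounds, is how a bromo or a methoxy group would behave in place of chloro at this position on the ring, and how a morpholin-4-yl group would compare at the end of the chain.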